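The compounds below may be only part of what the source reports. "The series", "measured", "known", "first", "only" and "open" are said of these compounds alone.

Of the compounds shown here, three built on one shared core have been tested in a functional assay on the whole organism with Rattus norvegicus as the target, with a stated time of 4 h, at a dose of 40 mg/kg by the intraperitoneal route; on this read-out lower numbers stand for less inhibition and higher numbers for more inhibition at the one dose given (going by the name of the read-out). Compound 1 `Cc1nc2c(COc3ccccc3)cccn2c1C` gives 48%. Compound 2 `Cc1nc2c(OCc3ccccc3)cccn2c1C(N)=O` gives 42%. Compound 3 `CCOCc1c(C)nc2c(OCc3ccccc3)cccn12` gives 84%, the highest of the three, beyond the scatter above both others. For the measured compounds named here, the only single-place step among them is a number 42 percentage points higher from compound 2 to compound 3 (beyond the scatter), which is ethoxymethyl in place of carbamoyl on an aromatic carbon.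

Compound 4 `CCCCC(=O)OCc1c(C)nc2c(OCc3ccccc3)cccn12` has not yet been measured. It differs from compound 3 in butylcarbonyl in place of ethyl on an oxygen on a saturated carbon. Going by the values given here, no measured step touches this place: the step from compound 2 to compound 3 exchanged a group on the aromatic carbon, and compounds 1 and 2 differ in more than one place, so only their values can be set side by side. The change keeps the oxygen on the saturated carbon that compound 3 carries, while the entering butylcarbonyl brings more heavy atoms and one hydrogen-bond acceptor; nothing measured shows what that does. The account therefore expects compound 4 to stay near compound 3, with a small move downward, a step of a number 14 percentage points lower from compound 3 to compound 4 (beyond the scatter), though a reading anywhere around it is plausible. The estimate for compound 4 in this assay is 70%, between 40% and 95%.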

Compound 4, a percentage reported as inhibition, in the whole organism at one dose (the size of the read-out at that dose, not a potency): 45%
Estimate against measurement, compound 4: 25 percentage points above, and the stated range covers the measured number.
By their numbers in this assay, from the lowest: compounds 2, 4 and 1 (each within the scatter of the next); then compound 3.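

For the compounds shown here, this is the first measured change on the oxygen on a saturated carbon, and in this assay butylcarbonyl in place of ethyl there gives a number 39 percentage points lower from compound 3 to compound 4 (beyond the scatter), so the number depends strongly on what that oxygen carries and not on the oxygen alone. Against carbamoyl on the aromatic carbon, ((butylcarbonyl)oxy)methyl gives a number 3 percentage points higher from compound 2 to compound 4 (within the scatter), which leaves those two groups indistinguishable here, and among the three groups compared at that carbon only ethoxymethyl stands apart. No measurement on hand accounts for the size of the step from ethyl to butylcarbonyl.

As far as these compounds go, it stays open whether the large step belongs to the carbonyl or to the length of the chain, since a butyl ether or a small acetyl ester on the same oxygen would be needed to separate the two. From the compounds shown here alone, it also stays open how a free hydroxyl or an amine in place of the ethoxy group would read, and whether a longer or branched ether would hold the number of compound 3 or move it.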